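Adding a methoxy to compound 2: expected effect on cytotoxicity

The compounds below may be only part of what the source reports. "The series", "measured", "known", "first", "only" and "open" are said of these compounds alone.

The series rests on two measured compounds. Compound 1 `COc1ccc(CCC[C@H]2C[C@@H]([C@@H](O)c3ccc(OC)c(OC)c3)CO[C@@H]2c2ccc(OC)c(OC)c2)cc1OC` carries a saturated chain, and in a functional assay on HeLa cells (Homo sapiens) for cytotoxicity, read by WST assay, with a stated time of 48 h (a higher number here means a weaker inhibitor, a lower number a stronger inhibitor), compound 1 gives 37700 nM. Compound 2 `COc1ccc([C@H]2OC[C@H]([C@@H](O)c3ccc(OC)c(OC)c3)C[C@@H]2C/C=C/c2ccc(OC)c(OC)c2)cc1` carries an unsaturated chain, and in this assay compound 2 gives 46700 nM. Compound 2 holds the highest of the two numbers, but its nearest neighbour, compound 1, lies within the scatter, so the two values cannot be told apart. For the measured compounds named here, no single-point step between them is available.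

Compound 3 `COc1ccc(/C=C/C[C@H]2C[C@@H]([C@@H](O)c3ccc(OC)c(OC)c3)CO[C@@H]2c2ccc(OC)c(OC)c2)cc1OC` is the unmeasured partner of compound 2. The change is methoxy in place of hydrogen on an aromatic carbon. Since both measured compounds sit close together, a step no larger than the scatter is expected, with no direction favoured; the step of a 1.2-fold lower number from compound 2 to compound 3 (0.07 log units; within the scatter) is the estimated outcome. Compound 3 is therefore expected to give about 40000 nM in this assay, with a likely range from 15000 nM to 100000 nM.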

Compound 3, half-maximal inhibitory concentration: 23800 nM
For compound 3 the middle estimate is 1.7-fold (0.23 log units) above the measured one; the measured number falls inside the stated range.
By their numbers in this assay, from the lowest: compounds 3, 1 and 2 (each within the scatter of the next).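

Compound 3 gives the series its first single-place comparisons in this assay. Methoxy in place of hydrogen on the aromatic carbon ortho to a methoxy group, which turns 4-methoxyphenyl into 3,4-dimethoxyphenyl, gives a 2.0-fold lower number from compound 2 to compound 3 (0.29 log units; within the scatter) and stays within the scatter. The chain change, 2-(3,4-dimethoxyphenyl)ethenyl in place of 2-(3,4-dimethoxyphenyl)ethyl, gives a 1.6-fold lower number from compound 1 to compound 3 (0.20 log units; within the scatter) and also stays within the scatter, so neither change separates the compounds here. Nothing is available here that would account for these numbers.

On these data alone, whether a different group on that aromatic carbon, such as a hydroxyl, an ethoxy or an amine, would give a step beyond the scatter remains open. The same holds for a longer chain or a carboxylic acid at the end of the chain on the shared core.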